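The source may report more compounds than this note shows. Statements on the series, on what has been measured and on what is new or still open speak of the compounds shown alone.

Compound 1 `CCNC(=O)c1cc(N)c(Nc2ccc(C#N)cc2)cc1Oc1c(C)cc(/C=C/C#N)cc1C` is an amide bearing an ethylamino group on its carbonyl carbon. For the measured compounds named here, in an ADME assay on liver (Homo sapiens) for metabolic stability, read by LC-MS, using S9 fraction and NADPH, with a stated time of 45 min, tested at 1 uM (a higher number here means that the compound lasts longer, a lower number that the compound disappears faster), compound 1 gives 1.02 h, the second highest of the three numbers known. Compound 2 `Cc1cc(/C=C/C#N)cc(C)c1Oc1cc(Nc2ccc(C#N)cc2)c(N)cc1C(=O)N1CC1` carries an aziridin-1-yl on that carbonyl carbon and gives 1.83 h; the step of a 1.8-fold higher number from compound 1 to compound 2 (0.25 log units; within the scatter) is within the scatter. Compound 3 `COC(=O)c1cc(N)c(Nc2ccc(C#N)cc2)cc1Oc1c(C)cc(/C=C/C#N)cc1C` is the methyl ester, giving 0.128 h, and the step of an 8.0-fold lower number from compound 1 to compound 3 (0.90 log units; beyond the scatter) is beyond the scatter, as is a 14-fold lower number from compound 2 to compound 3 (1.16 log units; beyond the scatter).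

Compound 4 `CNC(=O)c1cc(N)c(Nc2ccc(C#N)cc2)cc1Oc1c(C)cc(/C=C/C#N)cc1C` differs from compound 1 by hydrogen in place of methyl on a saturated chain carbon bound to an amide-type nitrogen. Both measured steps touch the same carbonyl substituent: exchanging the ethylamino for another amine-type group left the number within the scatter, while exchanging it for methoxy lowered it clearly. Trimming the chain of the amine substituent keeps the amide intact, so the expected step of a 1.0-fold lower number from compound 1 to compound 4 (0.01 log units; within the scatter) lies within the scatter. Compound 4 is therefore estimated at 1 h, with a range from 0.5 h to 2.1 h.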

Compound 4, half-life: 1.6 h
For compound 4 the middle estimate is 1.6-fold (0.20 log units) below the measured one, and the stated range covers the measured number.
By their numbers in this assay, from the lowest: compound 3; then compounds 1, 4 and 2 (each within the scatter of the next).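

In this assay, ethyl to methyl on the amide nitrogen gives a 1.6-fold higher number from compound 1 to compound 4 (0.20 log units; within the scatter), so removing this one methyl from the saturated chain carbon bound to an amide-type nitrogen leaves the half-life within the scatter. The methylamino amide also lies within the scatter of the aziridin-1-yl amide (a 1.1-fold lower number from compound 2 to compound 4 (0.06 log units; within the scatter)), whereas the exchange of methoxy for methylamino on the carbonyl carbon gives a 13-fold higher number from compound 3 to compound 4 (1.10 log units; beyond the scatter), so each of the three amides now stands clear of the methyl ester, compound 3. Nothing available accounts for this separation between the amides and the ester.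

The compounds shown leave open whether a propyl, isopropyl or cyclopropyl group on the amide nitrogen would stay within this range. They also do not show how the unsubstituted amide or a carboxylic acid at the same carbonyl carbon would compare.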